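The source may hold more compounds than are shown below. What is called first, only, known or untested is meant among the compounds shown, and "the series" means these compounds.

Series notes. Among the measured compounds shown here, compound 1 `O=C(NC1(C(=O)NO)CCC1)c1ccc(C#Cc2ccccc2)cc1` gives 5000 nM in a physicochemical assay for solubility (a higher number here means a more soluble compound, a lower number a less soluble compound), the only numerical value so far. Compound 2 `O=C(NC1(C(=O)NO)CCCCC1)c1ccc(C#Cc2ccccc2)cc1` reaches only the assay limit, < 1000 nM. Compound 3 `O=C(NC1(C(=O)NO)CCN(Cc2ccccc2)CC1)c1ccc(C#Cc2ccccc2)cc1` likewise stops at the limit, < 1000 nM. Compound 1 therefore stands alone as a measured number, the other two sitting at the limit of < 1000 nM in this assay, at which 2 of the 3 values shown sit. Compound 4 `CSC[C@H](NC(=O)c1ccc(C#Cc2ccccc2)cc1)C(=O)NO` differs from compound 1 in one place: a group of 8 heavy atoms (4 carbon, 1 nitrogen, 2 oxygen, 1 sulfur; no ring) in place of a group of 8 heavy atoms (5 carbon, 1 nitrogen, 2 oxygen; one four-membered non-aromatic ring of carbon only), on an amide-type nitrogen. For the measured compounds named here, no step between two measured compounds is available to calibrate this change. The expected step from compound 1 to compound 4 in this assay, a 1.2-fold higher number from compound 1 to compound 4 (0.08 log units; within the scatter), is small, not beyond the usual scatter, and slightly upward if anything. Compound 4 is estimated at 6000 nM, with a range of 2000 nM to 20000 nM.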

Compound 4, solubility: 2000 nM
Estimate against measurement, compound 4: 3.0-fold (0.48 log units) above; measured number inside the range.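

Compound 4 gives the series a second number rather than a limit in this assay: the limit of < 1000 nM in this assay, at which 2 of the 4 values shown sit. Among the compounds shown here, on the amide-type nitrogen, the ringless group with its sulfur in place of 1-(hydroxycarbamoyl)cyclobutyl gives a 2.5-fold lower number from compound 1 to compound 4 (0.40 log units; beyond the scatter) and this is the first readable step at this position. It is modest and rests on a single pair, so it sets no trend.

One step cannot separate losing the ring from gaining the sulfur. Still open, as far as these compounds go, is how a chain carrying an amine or a carboxylic acid would read at this position.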